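Methyl ester in place of cyclopropyl ketone on the core

The compounds below may be only part of what the source reports. "The series", "measured", "known", "first", "only" and "open" are said of these compounds alone.

Measured so far:
compound 1 `C[C@@H]1C[C@@H]1C(=O)N1CC2CNCC2C1` gives 1200 nM in an assay on SHEP1 cells for agonist activity at Neuronal acetylcholine receptor; alpha4/beta2 (Homo sapiens), read by FLIPR and calcium flux; a higher number here means that more compound is needed for the effect, a lower number that less compound is needed
compound 2 `COC(=O)N1CC2CNCC2C1` gives "not determined" (no result reported) in this assay
compound 3 `O=C(C1CC1)[C@H]1C[C@H]2CNC[C@H]2C1` gives 18 nM in this assay

Compound 3 stands at the lowest number of the two reported in this assay; compound 1 sits far higher, and the gap between the two lies well beyond the usual scatter. Compound 2 contributes no number. Compound 1 and compound 3 also differ in their core, so the two give no single-point comparison.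

Compound 4 `COC(=O)[C@H]1C[C@H]2CNC[C@H]2C1` keeps the core of compound 3 and changes only the substituent on the carbonyl: methoxy in place of cyclopropyl on a carbonyl carbon. Within the data shown here, no measured pair in this set isolates such a change, so the expectation rests on compound 3 alone as the anchor. A moderate shift towards a higher number in this assay is expected, so that a 6.7-fold higher number from compound 3 to compound 4 (0.82 log units; beyond the scatter) is estimated to lie outside the scatter. This expected step is estimated to stay short of the gap that compound 3 and compound 1 show. Compound 4 is therefore estimated at 120 nM in this assay, within a range from 25 nM to 600 nM.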

Compound 4, half-maximal effective concentration: 1200 nM
Compound 4: the middle estimate sits 10-fold (1.00 log units) below what was measured; measured number outside the range, above it.
By their numbers in this assay, from the lowest: compound 3; then compounds 1 and 4 (each within the scatter of the next).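

In this assay, methoxy in place of cyclopropyl on a carbonyl carbon gives a 67-fold higher number from compound 3 to compound 4 (1.82 log units; beyond the scatter). Among these compounds, this is the first step that changes one place only, and it shows that the number responds strongly to the group on this carbonyl carbon, with the cyclopropyl ketone of compound 3 holding the low value and the methyl ester of compound 4 losing it. Nothing at hand accounts for the size of this step.

As far as these compounds go, with a single pair, it remains open whether the low number depends on the three-membered ring itself or on a carbon group at this place in general; an ethyl or isopropyl ketone would separate the two. From the compounds shown here alone, how an amide at this carbonyl would read, and whether the same change behaves alike on another core, also remains open.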